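The compounds below may be only part of what the source reports. "The series", "measured", "known", "first", "only" and "open" are said of these compounds alone.

Compound 1 `CC(C)(C)OC(=O)N1C[C@H](Nc2nc3cc(F)ccc3[nH]2)[C@@H](OC(=O)c2ccc(-c3ccccc3)cc2)C1`: 1.5 10^-6 cm/s
Compound 2 `Cc1ccc2[nH]c(N[C@H]3CNC[C@@H]3OC(=O)c3ccc(-c4ccccc4)cc3)nc2c1`: 4.8 10^-6 cm/s

Among the compounds with values here, both values come from an ADME assay on MDCK cells (Canis lupus familiaris) for permeability, in the apical to basolateral direction, tested at 50 uM (on this read-out higher numbers stand for higher permeability and lower numbers for lower permeability), and are the only measurements so far. Compound 2 gives 4.8 10^-6 cm/s and stands highest of the two, with compound 1 at 1.5 10^-6 cm/s lower by a gap beyond the scatter. Compound 3 `Cc1ccc2[nH]c(N[C@H]3CN(C(=O)c4ccccc4)C[C@@H]3OC(=O)c3ccc(-c4ccccc4)cc3)nc2c1` is still to be measured and carries one change from compound 2 (benzoyl in place of hydrogen on an amine nitrogen in a ring), benzoyl in place of hydrogen on an amine nitrogen in a ring. Within the data shown here, no step between measured compounds shows a single change, so any expectation here is rough. A modest fall is expected (a 2.2-fold lower number from compound 2 to compound 3 (0.34 log units; beyond the scatter)) and it may not clear the scatter. Among the measured compounds shown here, the sole support is that compound 1 also has its amine nitrogen in a ring substituted and gives 1.5 10^-6 cm/s on this read-out. For compound 3 the estimated value is 2.2 10^-6 cm/s with an expected range from 0.7 10^-6 cm/s to 6.5 10^-6 cm/s on repeat measurement.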

Compound 3, apparent permeability: 5.2 10^-6 cm/s
Compound 3: middle estimate off by 2.4-fold (0.37 log units), on the low side, within the range that was stated.
By their numbers in this assay, from the lowest: compound 1; then compounds 2 and 3 (each within the scatter of the next).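

Benzoyl in place of hydrogen on the amine nitrogen in the ring gives a 1.1-fold higher number from compound 2 to compound 3 (0.03 log units; within the scatter) in this assay, the first single-change step at this position. At this nitrogen, then, the free hydrogen can give way to a benzoyl group, with its six-membered aromatic ring and carbonyl, without a shift beyond the scatter on this read-out. Nothing measured here explains why the read-out holds across this change.

Going by these compounds, whether other groups on this nitrogen, such as an acetyl, a methyl or a longer chain, would behave in the same way remains open. Also open, on these data alone, is whether the step would look the same with another group in place of the (5-methyl-1H-benzimidazol-2-yl)amino group.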